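Bicyclic urea replacement on the shared piperazine core

The source may report more compounds than this note shows. Statements on the series, on what has been measured and on what is new or still open speak of the compounds shown alone.

Compound 1 `O=C(Nc1cccc2nonc12)N1CCN(Cc2cccc(Oc3ccc(Cl)cc3)c2)CC1` stands lowest of the two numbers in an assay on isolated protein for inhibition of Fatty-acid amide hydrolase 1 (Rattus norvegicus), with a stated time of 60 min (on this read-out higher numbers stand for weaker inhibition and lower numbers for stronger inhibition), at 120 nM. Compound 2 `O=C(Nc1cccc2cn[nH]c12)N1CCN(Cc2cccc(Oc3ccc(Cl)cc3)c2)CC1` gives 6000 nM in this assay, and the step of a 50-fold higher number from compound 1 to compound 2 (1.70 log units; beyond the scatter) shows how much a change of this bicyclic group can cost. Compound 3 `O=C(Nc1cccn2ccnc12)N1CCN(Cc2cccc(Oc3ccc(Cl)cc3)c2)CC1` carries a group of 9 heavy atoms (7 carbon, 2 nitrogen; one five-membered aromatic ring with 2 hetero atoms, one six-membered aromatic ring with 1 hetero atom) in place of a group of 9 heavy atoms (6 carbon, 2 nitrogen, 1 oxygen; one five-membered aromatic ring with 3 hetero atoms, one six-membered aromatic ring of carbon only), on an amide-type nitrogen. For the measured compounds named here, only that one measured step bears on it, and it sets the scale; a rise beyond the scatter, though smaller than the one seen for compound 2, is expected, a 5.8-fold higher number from compound 1 to compound 3 (0.77 log units; beyond the scatter). Compound 3 is therefore estimated at 700 nM in this assay, within 120 nM to 4000 nM.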

Compound 3, half-maximal inhibitory concentration: 3500 nM
The estimate for compound 3 lay 5.0-fold (0.70 log units) below the measured number; the measured number falls inside the stated range.
By their numbers in this assay, from the lowest: compound 1; then compounds 3 and 2 (each within the scatter of the next).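

In this assay, a second replacement of the bicyclic group on the amide-type nitrogen is also costly (a 29-fold higher number from compound 1 to compound 3 (1.46 log units; beyond the scatter)), so the large loss is not confined to the group of compound 2. The two replacements are not separated (a 1.7-fold lower number from compound 2 to compound 3 (0.23 log units; within the scatter)), although only the group of compound 3 has a hetero atom in its six-membered ring. No measured property bears on these losses. Open, on these data alone, is whether a plain phenyl group at this amide-type nitrogen would stay with compound 1 or fall with compound 2 and compound 3.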